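A few compounds are considered here, and "the series" means these few. Any claim that something is new, unique, unknown or untested is made for them only; others in the source may bear on it.

Measured so far:

Compound 1, `Cc1nn(C)c(C)c1-c1ccc(-c2nnc(N(C)Cc3ccc4nccn4c3)o2)c(F)c1`, gives 3.2 in a physicochemical assay for lipophilicity, at pH 7.4; on this read-out higher numbers stand for higher lipophilicity and lower numbers for lower lipophilicity.
Compound 2, `Cc1cc(-c2c(C#N)nn(C)c2C)ccc1-c1nnc(N(C)Cc2ccc3nccn3c2)o1`, gives 3.4 in this assay.
Compound 3, `Cc1cc(-c2c(C)nn(C)c2C)ccc1-c1nnc(N(C)Cc2ccc3ncc(-c4cnn(C)c4)n3c2)o1`, gives 4 in this assay.

Among these three, compound 3 stands highest in this assay; its distance to compound 2 and its larger distance to compound 1 both lie beyond the usual scatter of this kind of measurement, so it is the most lipophilic of the three on this read-out. Compound 4, `Cc1cc(-c2c(C)nn(C)c2C)ccc1-c1nnc(N(C)Cc2ccc3ncc(-c4cnn(CCN(C)C)c4)n3c2)o1`, has not yet been measured. It is built from compound 3 by one change: (dimethylamino)methyl in place of hydrogen on a saturated chain carbon bound to an aromatic nitrogen. Going by the values given here, nothing in the measured set shows the effect of this particular change, so no measured step can be cited for it. The expectation is nonetheless that the value of compound 4 will fall rather than rise, and by more than the scatter, so that the step from compound 3 to compound 4 is estimated at a number 1.20 log units lower from compound 3 to compound 4 (beyond the scatter). On that basis compound 4 is expected to come out at about 2.8, with a range from 2 to 3.6.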

Compound 4, distribution coefficient: 3.5
Compound 4: middle estimate off by 0.70 log units, on the low side; measured number inside the range.
By their numbers in this assay, from the lowest: compounds 1, 2 and 4 (each within the scatter of the next); then compound 3.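

In this assay, putting (dimethylamino)methyl in place of hydrogen on a saturated chain carbon bound to an aromatic nitrogen, which turns methyl into 2-(dimethylamino)ethyl, gives a number 0.50 log units lower from compound 3 to compound 4 (beyond the scatter), a modest step. Going by these compounds alone, no earlier pair of compounds differed at this place, so this is the first reading of how the number responds to a change there, and it shows that this extension moves the read-out by more than the scatter. Nothing shown here accounts for the size of this step.

As far as these compounds go, what a longer chain ending in the same dimethylamino group would give at this place remains open. So does the outcome with a different end group on the 2-carbon chain, such as a hydroxyl, a primary amine or a carboxylic acid.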